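This account rests on a few compounds, and the source may have more. Where it says the series, first, only, none or still open, it means among the compounds named here.

Measured compounds in an ADME assay on WI-38 cells (Homo sapiens) for cytotoxicity, read by MTT assay, with a stated time of 72 h; on this read-out lower numbers stand for stronger inhibition and higher numbers for weaker inhibition:
compound 1 `CN(C)CCn1cnnc1-c1cc(Oc2ccc(NC(=O)N/N=C/c3ccc(O)c(F)c3)cc2F)ccn1`: "not determined" (no result reported)
compound 2 `CN(C)CCn1cnnc1-c1cc(Oc2ccc(NC(=O)N/N=C/c3ccc(O)c(O)c3)cc2F)ccn1`: "not determined" (no result reported)
compound 3 `CN(C)CCn1cnnc1-c1cc(Oc2ccc(NC(=O)N/N=C/c3ccccc3O[N+](=O)[O-])cc2F)ccn1`: 6860 nM

Among the measured compounds shown here, compound 2 stands without a single number in this assay; the same holds for compound 1, so compound 3 carries the only reported value of the series, and compound 2 cannot be placed against it. Compound 4 `CN(C)CCn1cnnc1-c1cc(Oc2ccc(NC(=O)N/N=C/c3ccc(F)cc3F)cc2F)ccn1` differs from compound 2 by 2,4-difluorophenyl in place of 3,4-dihydroxyphenyl on a carbon with a double bond to nitrogen. For the measured compounds named here, no step between measured compounds exists to size this change, and with no number for compound 2 the step from compound 2 to compound 4 cannot be reckoned; the only guide is the value of compound 3, and on that guide a result close to compound 3 is expected, in no particular direction. Compound 4 is estimated at 8000 nM in this assay, with a range from 3000 nM to 25000 nM.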

Compound 4, half-maximal inhibitory concentration: 5030 nM
Compound 4: middle estimate off by 1.6-fold (0.20 log units), on the high side; measured number inside the range.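

In this assay, among the compounds shown here, 2,4-difluorophenyl in place of 2-(nitrooxy)phenyl on a carbon with a double bond to nitrogen gives a 1.4-fold lower number from compound 3 to compound 4 (0.13 log units; within the scatter), the first readable step at this position. This exchange therefore separates the two compounds by no more than the usual scatter, while the step from compound 2 to compound 4 cannot be read. Nothing measured here accounts for this result.

Open, from the compounds shown here alone, is how a phenyl carrying a carboxylic acid or a dimethylamino group would read at this position.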